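Piperazine amide series: melanocortin receptor 4 binding, compound 4

The compounds below may be only part of what the source reports. "The series", "measured", "known", "first", "only" and "open" are said of these compounds alone.

Measured so far:
compound 1 `COc1cc(Cl)ccc1C[C@@H](C)C(=O)N1CCN(c2ccc(C)cc2[C@@H](N)CC(C)C)CC1`: 8.1 nM
compound 2 `Cc1ccc(N2CCN(C(=O)[C@H](C)Cc3ccc(Cl)cc3F)CC2)c([C@@H](N)CC(C)C)c1`: 20 nM
compound 3 `Cc1cc(CC(C)C(=O)N2CCN(c3ccc(C(F)(F)F)cc3[C@@H](N)CC(C)C)CC2)ccc1Cl`: 71 nM

In an assay on HEK293 cells for displacement of a labelled ligand from Melanocortin receptor 4 (Homo sapiens) (on this read-out higher numbers stand for weaker inhibition and lower numbers for stronger inhibition), compound 3 gives the highest number of the three; compound 2 sits nearer to it, compound 1 furthest away, both gaps beyond the scatter. Among the measured compounds shown here, the one single-point step on record, a 2.5-fold higher number from compound 1 to compound 2 (0.39 log units; beyond the scatter), concerns the aryl ring of the acyl side and is modest.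

Compound 4 `CC(C)C[C@H](N)c1cc(C(F)(F)F)ccc1N1CCN(C(=O)CCC(=O)c2ccc(Cl)cc2)CC1` differs from compound 3 by 2-((4-chlorophenyl)carbonyl)ethyl in place of 1-(4-chloro-3-methylbenzyl)ethyl on a carbonyl carbon. For the measured compounds named here, no measured step covers this kind of exchange, so the one step on record gives no direct guide, and the expectation rests only on the position of compound 3. A step of a 1.8-fold higher number from compound 3 to compound 4 (0.26 log units; within the scatter) is expected, i.e. a further modest rise with wide uncertainty. For compound 4 in this assay the estimate is 130 nM, within 30 nM to 600 nM.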

Compound 4, inhibition constant: 820 nM
The estimate for compound 4 lay 6.3-fold (0.80 log units) below the measured number; measured number outside the range, above it.
By their numbers in this assay, from the lowest: compound 1; then compound 2; then compound 3; then compound 4.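

In this assay, the place on the carbonyl carbon proves far more sensitive than the acyl-side aryl ring change alone suggested: a 12-fold higher number from compound 3 to compound 4 (1.06 log units; beyond the scatter), against the modest 2.5-fold higher number from compound 1 to compound 2 (0.39 log units; beyond the scatter). The exchange keeps the heavy-atom count and a chlorinated six-membered aromatic ring, so these alone do not preserve the binding number. No measurement on record accounts for the rise.

The branching methyl, the ring methyl and the chain carbonyl all change together, and the compounds shown do not separate them. A 3-(4-chlorophenyl)propyl group, with no chain carbonyl, would isolate that feature.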